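This account rests on a few compounds, and the source may have more. Where it says the series, first, only, none or still open, it means among the compounds named here.

Compound 1 `Cc1ccc(CNC(=O)c2nn(-c3ccc(F)cc3)c(CC[C@@H](O)C[C@@H](O)CC(=O)O)c2C(C)C)cc1`: 800 nM
Compound 2 `CC(C)c1c(C(=O)N2CCC[C@H](c3ccccc3)C2)nn(-c2ccc(F)cc2)c1CC[C@@H](O)C[C@@H](O)CC(=O)O`: 310 nM
Compound 3 `CC(C)c1c(C(=O)NCc2ccccc2)nn(-c2ccc(F)cc2)c1OC[C@@H](O)C[C@@H](O)CC(=O)O`: 880 nM

All three compounds were tested in a functional assay on L6 cells (Rattus norvegicus) for inhibition; on this read-out lower numbers stand for stronger inhibition and higher numbers for weaker inhibition. Compound 3 gives 880 nM, which lies within the usual scatter of compound 1 at 800 nM, while compound 2 shows a clearly lower number, 310 nM.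

Compound 4 `CC(C)c1c(C(=O)N2CCCC2c2ccccc2)nn(-c2ccc(F)cc2)c1OC[C@@H](O)C[C@@H](O)CC(=O)O` keeps the core of compound 3 and differs in one place: 2-phenylpyrrolidin-1-yl in place of benzylamino on a carbonyl carbon. The amide on the carbonyl carbon thus changes from an open benzylamino group to a ring-bearing 2-phenylpyrrolidin-1-yl group.

For the measured compounds named here, the one measured step that bears on this is a 2.6-fold lower number from compound 1 to compound 2 (0.41 log units; beyond the scatter), for 3-phenylpiperidin-1-yl in place of (4-methylbenzyl)amino on a carbonyl carbon. That step is modest but beyond the scatter. Going by the values given here, it is only a single example, its groups are not the same, and its compounds differ from compound 3 elsewhere, so it is an uncertain guide.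

A similar modest move towards a lower number is expected in this assay, and the estimated change is a 2.2-fold lower number from compound 3 to compound 4 (0.34 log units; beyond the scatter). The estimate for compound 4 is 400 nM, with an expected range of 140 nM to 1100 nM.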

Compound 4, half-maximal inhibitory concentration: 4340 nM
The estimate for compound 4 lay 11-fold (1.04 log units) below the measured number; measured number outside the range, above it.
By their numbers in this assay, from the lowest: compound 2; then compounds 1 and 3 (each within the scatter of the next); then compound 4.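

On the core of compound 3, putting 2-phenylpyrrolidin-1-yl in place of benzylamino on the carbonyl carbon weakens inhibition in this assay, with a 4.9-fold higher number from compound 3 to compound 4 (0.69 log units; beyond the scatter). Set beside a 2.6-fold lower number from compound 1 to compound 2 (0.41 log units; beyond the scatter), this shows that exchanging an open benzyl-type amide for a ring-bearing one does not move the number in one fixed direction: one of these two pairs goes down and the other goes up. The two pairs differ both in their ring groups and in the core, and nothing measured here accounts for the opposite directions.

Going by these compounds, whether the ring group or the core decides the direction stays open: 3-phenylpiperidin-1-yl appears only on the core of compound 2, and 2-phenylpyrrolidin-1-yl only on the core of compound 4. Also open, on these data alone, is how plain pyrrolidin-1-yl, without the phenyl ring, or benzyl(methyl)amino, which keeps the open chain but has no amide hydrogen, would behave on this carbonyl carbon.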